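A Second Methyl on the Imidazole of Compound 2

A few compounds are considered here, and "the series" means these few. Any claim that something is new, unique, unknown or untested is made for them only; others in the source may bear on it.

Going by the values given here, compound 2 `Cc1cc(Cl)c(-c2cn(C)cn2)cc1NC(=O)c1ccc(OCc2ccccn2)cc1` is the one compound in this small set with an actual number in a physicochemical assay for solubility, at pH 7.4; a higher number here means a more soluble compound, a lower number a less soluble compound: compound 2 gives 20000 nM. Compound 1 `Cc1cc(Cl)c(-c2ncc[nH]2)cc1NC(=O)c1ccc(OCc2ccccn2)cc1` sits at a limit of this assay; in this assay compound 1 gives < 1000 nM, a limit rather than a number (the limit of < 1000 nM in this assay, at which 1 of the 2 values shown sits). Among the compounds with values here, the single measured step, an at least 20-fold higher number from compound 1 to compound 2 (1.30 log units; beyond the scatter), is therefore known only as a lower bound on its size.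

Compound 3 `Cc1cc(Cl)c(-c2cn(C)c(C)n2)cc1NC(=O)c1ccc(OCc2ccccn2)cc1` differs from compound 2 by methyl in place of hydrogen on an aromatic carbon. The measured step bears on this change only loosely, since it exchanged one imidazolyl for another, with the methyl entering on a ring nitrogen, whereas here the ring already carries that methyl and a second methyl is added on an aromatic carbon. Within the data shown here, no measured step adds a methyl to carbon, so the expectation is for no shift beyond the scatter, no change at the digits printed from compound 2 to compound 3 (within the scatter). Compound 3 is estimated in this assay at 20000 nM, with a range from 8000 nM to 50000 nM.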

Compound 3, solubility: < 1000 nM
Compound 3 gave a limit, no number; the forecaster's own chance of this, stated with the estimate: 5%; middle value at least 20-fold (1.30 log units) away from the limit.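

The aromatic carbon between two ring nitrogen atoms of the 1-methyl-1H-imidazol-4-yl group is not a silent place in this assay: methyl in place of hydrogen there gives an at least 20-fold lower number from compound 2 to compound 3 (1.30 log units; beyond the scatter). The earlier step exchanged one imidazolyl for another, so it could not show what a single added carbon does at one position, whereas this change enters only 1 heavy atom and the step is still large and beyond the scatter. Compound 3 gives a limit and not a number, as compound 1 does, so the step between those two cannot be read: the limit of < 1000 nM in this assay, at which 2 of the 3 values shown sit.

The compounds shown hold only hydrogen and methyl on this carbon, so it remains open whether the step belongs to methyl in particular or would also appear with fluorine, an ethyl group or an amine there. How far compound 3 lies past its limit, and what accounts for so large a step from one methyl, also remain open.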